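Replacing thiophen-3-yl with 3-chlorophenyl: working notes

This account rests on a few compounds, and the source may have more. Where it says the series, first, only, none or still open, it means among the compounds named here.

Measured in a functional assay on HepG2 cells (Homo sapiens) for antiproliferative activity, read by MTT assay, with a stated time of 24 h; a higher number here means a weaker inhibitor, a lower number a stronger inhibitor:
- compound 1 `COc1ccc(/C=C/C(=O)c2ccc(OC)c3c2OC(C)(C)C=C3)c(F)c1` gives 7560 nM
- compound 2 `COc1ccc(C(=O)/C=C/c2ccc([N+](=O)[O-])cc2)c2c1C=CC(C)(C)O2` gives 2610 nM
- compound 3 `COc1ccc(C(=O)/C=C/c2ccsc2)c2c1C=CC(C)(C)O2` gives > 10000 nM (a limit, not a number)

Compound 3 stands at a limit, so it has no number (the limit of > 10000 nM in this assay, at which 1 of the 3 values shown sits).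

Compound 4 `COc1ccc(C(=O)/C=C/c2cccc(Cl)c2)c2c1C=CC(C)(C)O2` carries 3-chlorophenyl in place of thiophen-3-yl on a double-bonded chain carbon bound to a double-bonded chain carbon.

Three measured steps act at this same place. Two of them bring in thiophen-3-yl: one floor lies within the scatter (an at least 1.3-fold higher number from compound 1 to compound 3 (0.12 log units; that floor lies within the scatter)), and the other lies beyond it (an at least 3.8-fold higher number from compound 2 to compound 3 (0.58 log units; beyond the scatter)). The step between the two phenyl compounds is modest (a 2.9-fold lower number from compound 1 to compound 2 (0.46 log units; beyond the scatter)). Compound 4 also carries a phenyl ring, so these steps, read in reverse, point to a lower number in this assay, probably of modest size. Going by these compounds, the true size stays open, since it starts from a limit.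

The expected step is modest (an at least 1.6-fold lower number from compound 3 to compound 4 (0.22 log units; that floor lies within the scatter)).

The estimate for compound 4 is 6000 nM, with an expected range of 2500 nM to 12000 nM.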

Compound 4, half-maximal inhibitory concentration: > 10000 nM
Compound 4 ended at the assay's limit; the forecaster's own chance of this, stated with the estimate: 30%; middle value at least 1.6-fold (0.22 log units) away from the limit.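

In this assay compound 4 gives > 10000 nM, a limit and not a number, and the step from compound 3, itself at a limit, cannot be read. Set against 4-nitrophenyl, 3-chlorophenyl shows an at least 3.8-fold higher number from compound 2 to compound 4 (0.58 log units; beyond the scatter), while set against 2-fluoro-4-methoxyphenyl it shows only an at least 1.3-fold higher number from compound 1 to compound 4 (0.12 log units; that floor lies within the scatter). Carrying a phenyl ring at this place is thus not enough to bring the number under the limit, which a phenyl compound now shares with the thiophen-3-yl compound: the limit of > 10000 nM in this assay, at which 2 of the 4 values shown sit.

Going by these compounds, whether compound 3 and compound 4 differ at all stays open. Also open, on these data alone, is whether the lower number of compound 2 goes with the nitro group or with where it sits on the ring; a 3-nitrophenyl or 4-chlorophenyl group at this place would separate the two.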